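Furan for pyridine on a shared pyridine-carrying core

The source may report more compounds than this note shows. Statements on the series, on what has been measured and on what is new or still open speak of the compounds shown alone.

Compound 1 `Oc1ccc(-c2cc(-c3ccccn3)nc(-c3ccccc3Cl)c2)cc1` and compound 2 `Oc1ccc(-c2cc(-c3ccco3)nc(-c3ccccc3Cl)c2)cc1` differ in one place, (furan-2-yl in place of pyridin-2-yl on an aromatic carbon)
. In an assay on isolated protein for inhibition of DNA topoisomerase 1 (Homo sapiens), with a stated time of 30 min, tested at 100 uM (on this read-out higher numbers stand for a stronger effect at the one concentration tested and lower numbers for a weaker effect), compound 1 gives 5.2% and compound 2 gives 3.9%; the step of a number 1.3 percentage points lower from compound 1 to compound 2 (within the scatter) is small. Compound 3 `Oc1cccc(-c2cc(-c3cccc(Cl)c3)nc(-c3ccccn3)c2)c1` has the same atoms as compound 1 joined differently; how the two cores differ is not broken down here. In this assay compound 3 gives 0.4%. Compound 4 `Oc1cccc(-c2cc(-c3cccc(Cl)c3)nc(-c3ccco3)c2)c1` is not yet measured; it differs from compound 3 by furan-2-yl in place of pyridin-2-yl on an aromatic carbon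
, the same kind of change as from compound 1 to compound 2, though here the place is meta to a 3-chlorophenyl group and a 3-hydroxyphenyl group rather than a 2-chlorophenyl and a 4-hydroxyphenyl group. Because compound 1 to compound 2 gave a number 1.3 percentage points lower from compound 1 to compound 2 (within the scatter), the expected step is a number 0.6 percentage points higher from compound 3 to compound 4 (within the scatter). Compound 4 is estimated at 1%, between -5% and 8%.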

Compound 4, a percentage reported as inhibition, at one concentration (the size of the read-out at that concentration, not a potency): 5.5%
The estimate for compound 4 lay 4.5 percentage points below the measured number; measured number inside the range.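

In this assay, furan-2-yl in place of pyridin-2-yl gives a number 5.1 percentage points higher from compound 3 to compound 4 (within the scatter). Set beside the earlier step, the change behaves no differently on the two cores: the same change on two cores in this assay, a number 1.3 percentage points lower (within the scatter) from compound 1 to compound 2 and a number 5.1 percentage points higher (within the scatter) from compound 3 to compound 4, 6.4 percentage points apart, within the scatter of two such steps. This shows that the swap leaves the read-out within the scatter on both cores, but it does not show a real effect of the change in either direction, and with every number this small it cannot show how the change would carry over to a core with a stronger effect.

The compounds shown leave open whether a different group at this place, such as an amine or a carboxylic acid, would move the read-out beyond the scatter.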